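Esterifying the Acid Tail: Expected Cytotoxicity of Compound 3

The source may hold more compounds than are shown below. What is called first, only, known or untested is meant among the compounds shown, and "the series" means these compounds.

Two compounds from this series have been run in an ADME assay on HepG2 cells (Homo sapiens) for cytotoxicity, read by CellTiter-Glo and resazurin assay, with a stated time of 72 h; on this read-out higher numbers stand for an effect only at larger amounts of compound and lower numbers for an effect already at smaller amounts. Compound 1, `CC(C)N(Cc1cccc(OCCCCCC(=O)O)c1)C(=O)c1ccc(-c2ccc3c(c2)OCCO3)cc1`, reaches only a limit of the assay, > 21900 nM. Compound 2, `CC(C)N(Cc1cccc(OCCCCCC(=O)O)c1)C(=O)c1ccc(-c2cc3ccccc3n2S(=O)(=O)c2ccccc2)cc1`, likewise reaches only a limit of the assay, > 26000 nM. Compound 2 therefore stands at the limit of > 26000 nM in this assay, at which 1 of the 2 values shown sits, with no measurable effect within the concentrations tested.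

Compound 3, `CCOC(=O)CCCCCOc1cccc(CN(C(=O)c2ccc(-c3cc4ccccc4n3S(=O)(=O)c3ccccc3)cc2)C(C)C)c1`, has not been measured. It differs from compound 2 by ethyl in place of hydrogen on an oxygen next to a carbonyl group. For the measured compounds named here, no step between two measured compounds is available to show how such a change plays out in this assay, so the expectation rests only on the limit seen for compound 2. The step from compound 2 to compound 3 is expected to be a number no higher from compound 2 to compound 3 (the limit leaves the size open), which is none beyond the scatter. Compound 3 is therefore estimated at 26000 nM, with a range from 8000 nM to 60000 nM, most likely reported again as a limit.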

Compound 3, half-maximal effective concentration: > 26000 nM
Compound 3 was reported as a limit; the forecaster's own chance of this, stated with the estimate: 70%; the middle value lies on the limit itself.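

Compound 2 and compound 3 both reach only a limit of the assay, so no step can be read between them. The compounds shown leave open at what concentration any of them would affect these cells, and whether ethyl in place of hydrogen changes that concentration.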